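A few compounds are considered here, and "the series" means these few. Any claim that something is new, unique, unknown or untested is made for them only; others in the source may bear on it.

Compound 1 `Cn1nc(Cc2nnc(SCCCCCCCC(=O)Nc3ccc(Cl)cc3Cl)[nH]2)c2ccccc2c1=O`, compound 2 `Cn1nc(Cc2nnc(SCCCCCCCC(=O)Nc3ccc(Cl)cc3Cl)n2CCC(=O)O)c2ccccc2c1=O` and compound 3 `Cn1c(Cc2nn(CCC(=O)O)c(=O)c3ccccc23)nnc1SCCCCCCCC(=O)Nc1ccc(Cl)cc1Cl` were all run in an assay on NK92 cells for inhibition of interleukin-15 (Homo sapiens), read by AlphaScreen, with stated times of 30 min and 1 h; a lower number here means a stronger inhibitor, a higher number a weaker inhibitor. Compound 1 gives 280 nM and compound 2 gives 9500 nM. For compound 3 this assay reports only a limit, > 30000 nM. The difference between the cores of compound 2 and compound 3 is not broken down here. From compound 2 to compound 1 the change is hydrogen in place of 2-carboxyethyl on an aromatic nitrogen, and it brings a 34-fold lower number from compound 2 to compound 1 (1.53 log units; beyond the scatter). Compound 4 `Cn1c(Cc2n[nH]c(=O)c3ccccc23)nnc1SCCCCCCCC(=O)Nc1ccc(Cl)cc1Cl`, not yet measured, carries the same kind of change on compound 3: hydrogen in place of 2-carboxyethyl on an aromatic nitrogen. Here the place differs: the hydrogen enters on an aromatic nitrogen of a six-membered aromatic ring with 2 nitrogen, part of a fused system, rather than on a five-membered aromatic ring with 3 nitrogen. Within the data shown here, since compound 3 sits at the limit of > 30000 nM in this assay, at which 1 of the 3 values shown sits, no measured step bounds the gain. By analogy compound 4 is expected at 3000 nM, between 600 nM and 20000 nM, a step of an at least 10-fold lower number from compound 3 to compound 4 (1.00 log units; beyond the scatter).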

Compound 4, half-maximal inhibitory concentration: 20000 nM
Estimate against measurement, compound 4: 6.7-fold (0.82 log units) below; measured number inside the range.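

In this assay, hydrogen in place of 2-carboxyethyl on an aromatic nitrogen of the fused ring brings an at least 1.5-fold lower number from compound 3 to compound 4 (0.17 log units; that floor lies within the scatter). This is only a floor, so it shows that the change can be carried to the second core without raising the number, but not that the large gain is carried with it: the same change on two cores in this assay, a 34-fold lower number (1.53 log units; beyond the scatter) from compound 2 to compound 1 and an at least 1.5-fold lower number (0.17 log units; that floor lies within the scatter) from compound 3 to compound 4; the limit leaves it open whether they differ Compound 3 stands at a limit of the assay, > 30000 nM, and the size of the step on this core therefore stays unknown: the limit of > 30000 nM in this assay, at which 1 of the 4 values shown sits.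

The compounds shown leave open what a carboxymethyl group, a methyl ester or an amine would give in place of 2-carboxyethyl on either core. They also leave open where compound 3 truly lies.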